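Series notes: anilino group in place of methylpiperazine

A few compounds are considered here, and "the series" means these few. Any claim that something is new, unique, unknown or untested is made for them only; others in the source may bear on it.

Measured so far in a functional assay on the whole organism (strain Wister albino) for inhibition, with Rattus norvegicus as the target, read by paw edema, with a stated time of 1 h, at a dose of 50 mg/kg by the intraperitoneal route; on this read-out higher numbers stand for more inhibition at the one dose given (going by the name of the read-out) and lower numbers for less inhibition:
compound 1 `CCOC(=O)c1c(-c2ccc(Cl)cc2)cc(-c2ccccc2)nc1N1CCCCC1` gives 59.3%
compound 2 `CCOC(=O)c1c(-c2ccc(Cl)cc2)cc(-c2ccccc2)nc1N1CCN(C)CC1` gives 65.8%
compound 3 `CCOC(=O)c1c(-c2ccc(Cl)c(Cl)c2)cc(-c2ccccc2)nc1Nc1ccc(C)cc1` gives 59%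

Compound 2 holds the highest of the three numbers, yet the gaps to both neighbours are within the scatter: a number 6.5 percentage points higher from compound 1 to compound 2 (within the scatter), and compound 3 sits close to compound 2 as well. No order among the three can be claimed.

Compound 4 `CCOC(=O)c1c(-c2ccc(Cl)cc2)cc(-c2ccccc2)nc1Nc1ccc(OC)cc1` is the next case. ((4-methoxyphenyl)amino in place of 4-methylpiperazin-1-yl on an aromatic carbon). Going by the values given here, the one measured step that bears on this position, a number 6.5 percentage points higher from compound 1 to compound 2 (within the scatter), exchanged one saturated amine for another and stayed within the scatter. Among the compounds with values here, no measured step swaps a saturated amine for an arylamino group; compound 3 carries such a group but on a different core, so its value alone says little. Compound 4 is therefore expected to sit near compound 2, with a number 5.8 percentage points lower from compound 2 to compound 4 (within the scatter), giving an estimate of 60% within 45% to 75%.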

Compound 4, a percentage reported as inhibition, in the whole organism at one dose (the size of the read-out at that dose, not a potency): 33.3%
For compound 4 the middle estimate is 26.7 percentage points above the measured one; the measured number lies below the stated range.
By their numbers in this assay, from the lowest: compound 4; then compounds 3, 1 and 2 (each within the scatter of the next).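

Among the saturated amines on the shared core, the one step shown stayed within the scatter, whereas the (4-methoxyphenyl)amino group moves the read-out in this assay beyond it: a number 32.5 percentage points lower from compound 2 to compound 4 (beyond the scatter), and a number 26 percentage points lower from compound 1 to compound 4 (beyond the scatter). This position therefore responds to the exchange of either saturated ring for this arylamino group. Nothing measured here accounts for the drop. Still open, as far as these compounds go, is whether the drop follows the aromatic ring, the amino hydrogen or the methoxy group. Benzylamino or unsubstituted phenylamino at this position on the same core would help separate these.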